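The source may hold more compounds than are shown below. What is called first, only, known or untested is meant among the compounds shown, and "the series" means these compounds.

The measured compounds, in an ADME assay on HeLa cells (Homo sapiens) for cytotoxicity, read by MTT assay; a lower number here means a stronger inhibitor, a higher number a weaker inhibitor:

Compound 1, `CCN(CC)C(=O)CCC(=O)Oc1ccc(C[C@H]2C(=O)OC[C@@H]2Cc2ccc(OC)c(OC)c2)cc1OC`, gives 213000 nM.
Compound 2, `COc1ccc(C[C@H]2COC(=O)[C@@H]2Cc2ccc(OCc3cn(-c4ccc(Cl)cc4)nn3)c(OC)c2)cc1OC`, gives 279000 nM.
Compound 3, `COc1ccc(C[C@H]2COC(=O)[C@@H]2Cc2ccc(OCc3cn(-c4ccc(F)cc4)nn3)c(OC)c2)cc1OC`, reaches only a limit of the assay, >= 600000 nM.

Compound 3 therefore has no number of its own in this assay; what is known is that it sits at the limit of >= 600000 nM in this assay, at which 1 of the 3 values shown sits, so all that can be said is that it is the weakest of the three shown, the others standing at numbers rather than at a limit.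

The unmeasured compound 4, `COc1ccc(C[C@H]2COC(=O)[C@@H]2Cc2ccc(OCc3cn(-c4ccccc4)nn3)c(OC)c2)cc1OC`, differs from compound 3 in one place: hydrogen in place of fluoro on an aromatic carbon. Cut one bond further out, the change reads 4-fluorophenyl to phenyl. Among the compounds with values here, only one measured step touches this part of the molecule, an at least 2.1-fold higher number from compound 2 to compound 3 (0.33 log units; beyond the scatter), which shows that exchanging one halogen for another on this ring moved the number beyond the scatter, though only to a limit. Within the data shown here, no measured pair removes the halogen altogether, so the direction of the step from compound 3 to compound 4 cannot be read from the data; a step within the scatter, or a modest one in either direction, is equally open. On that basis compound 4 is expected to give about 500000 nM in this assay, between 200000 nM and 1500000 nM, which means an estimated step of an at least 1.2-fold lower number from compound 3 to compound 4 (0.07 log units; that floor lies within the scatter).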

Compound 4, half-maximal inhibitory concentration: 124000 nM
Compound 4: middle estimate off by 4.0-fold (0.61 log units), on the high side; the measured number lies below the stated range.
By their numbers in this assay, from the lowest: compounds 4, 1 and 2 (each within the scatter of the next, the first and the last beyond it). At a limit, above all of these: compound 3.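

In this assay, hydrogen in place of a halogen on the aromatic ring, para to a large group, lowers the number in both cases shown, giving a 2.3-fold lower number from compound 2 to compound 4 (0.35 log units; beyond the scatter) for chloro and an at least 4.8-fold lower number from compound 3 to compound 4 (0.68 log units; beyond the scatter) for fluoro, so this ring no longer rests on an exchange of one halogen for another alone. The second of these steps has only a floor, as compound 3 stands at a limit and not at a number: the limit of >= 600000 nM in this assay, at which 1 of the 4 values shown sits. Set against the open-chain group on the oxygen of compound 1, the 1-phenyl-1H-1,2,3-triazol-4-yl group cannot be told apart, with a 1.7-fold lower number from compound 1 to compound 4 (0.23 log units; within the scatter).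

Going by these compounds, only hydrogen, fluoro and chloro stand at this place on the ring, so it remains open whether a methoxy group, a nitrile, an amine or a carboxylic acid there would follow hydrogen or the halogens. On these data alone, it is also open how far compound 3 lies beyond its limit, and so how large the step from fluoro to hydrogen really is.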